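This account rests on a few compounds, and the source may have more. Where it says the series, first, only, none or still open, it means among the compounds named here.

Three members of the series carry a number in a functional assay on MDA-MB-231 cells (Homo sapiens) for cytotoxicity, read by MTT assay, with a stated time of 48 h; a lower number here means a stronger inhibitor, a higher number a weaker inhibitor. Compound 1 `COc1cc(N2C(=S)SCC2(O)c2ccc(Br)cc2)cc(OC)c1OC` gives 15.1 ug/mL in this assay, and compound 2 `COc1cc(N2C(=S)SCC2(O)c2ccc(Cl)cc2Cl)cc(OC)c1OC` gives 14.5 ug/mL; the step between them, a 1.0-fold lower number from compound 1 to compound 2 (0.02 log units; within the scatter), stays within the scatter. Compound 3 `COc1cc(-n2c(-c3ccc(F)cc3)csc2=S)cc(OC)c1OC` gives 19.5 ug/mL in this assay, the highest of the three numbers, though its gaps to compound 1 and to compound 2 both lie within the scatter, so no order among the three is established. Compound 4 `COc1cc(-n2c(-c3ccc(C)cc3)csc2=S)cc(OC)c1OC` differs from compound 3 by methyl in place of fluoro on an aromatic carbon. Within the data shown here, no measured step exchanges a group on an aromatic carbon of this ring; the only step in hand, a 1.0-fold lower number from compound 1 to compound 2 (0.02 log units; within the scatter), replaces one halogenated aryl group by another on a saturated ring carbon of the core of compound 1 and does not leave the scatter. On that slim basis no step beyond the scatter is expected in this assay. Compound 4 is therefore expected to give about 19 ug/mL in this assay, between 10 ug/mL and 38 ug/mL. The expected step is a 1.0-fold lower number from compound 3 to compound 4 (0.01 log units; within the scatter), estimated to stay within the scatter.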

Compound 4, half-maximal inhibitory concentration: 11.8 ug/mL
Beside the measured number, compound 4's estimate is 1.6-fold (0.21 log units) above it; low and high end bracket the measured number.
By their numbers in this assay, from the lowest: compounds 4, 2, 1 and 3 (each within the scatter of the next).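

In this assay, the change from 4-fluorophenyl to 4-methylphenyl gives a 1.7-fold lower number from compound 3 to compound 4 (0.22 log units; within the scatter), the first step read on an aromatic carbon of this ring, para to a large group. At this place, fluoro and methyl, each a single heavy atom with no hydrogen-bond donor or acceptor, are therefore not told apart in this assay, and the step gives no direction for further changes there. No measurement at hand bears on the origin of this step.

From the compounds shown here alone, whether an amine, a carboxylic acid or a longer chain such as butyl at this place would move the number beyond the scatter stays open. Also open, going by these compounds, is whether a series with larger steps would emerge from exchanging the trimethoxyphenyl part of the shared core.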